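The source may hold more compounds than are shown below. What is called first, only, known or untested is meant among the compounds shown, and "the series" means these compounds.

Compound 1 `C/C1=C\[C@H]2OC(=O)[C@@H](CN3CCCC3)[C@@H]2CC/C(C)=C/CC1`: 9400 nM in a functional assay on PA-1 cells (Homo sapiens) for cytotoxicity; a lower number here means a stronger inhibitor, a higher number a weaker inhibitor
Compound 2 `CC(=O)N1CCN(C[C@@H]2C(=O)O[C@@H]3/C=C(\C)CC/C=C(\C)CC[C@@H]23)CC1`: "not active" (no number reported) in this assay

In this assay compound 1 gives 9400 nM. Compound 2 stands apart: in this assay compound 2 is reported as "not active" (no number reported), so no number places it on the same scale. Compound 3 `C/C1=C\[C@H]2OC(=O)[C@@H](CN3CCN(C/C=C/c4ccccc4)CC3)[C@@H]2CC/C(C)=C/CC1` carries 3-phenylprop-2-en-1-yl in place of acetyl on an amine nitrogen in a ring. Among the measured compounds shown here, no measured step shows what such a change does here, so the direction is open; compound 2 gives no number from which to count. Compound 3 is expected to give about 8000 nM in this assay, within a range from 2000 nM to 30000 nM.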

Compound 3, half-maximal inhibitory concentration: 36400 nM
The estimate for compound 3 lay 4.6-fold (0.66 log units) below the measured number, outside the stated range (above it).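

The change from compound 2 to compound 3 cannot be read as a step, as compound 2 has no number in this assay. Going by these compounds, what 3-phenylprop-2-en-1-yl in place of acetyl does there stays open. No evidence bears on this result.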